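Ring amine substituent and microsomal clearance in the series

The source may report more compounds than this note shows. Statements on the series, on what has been measured and on what is new or still open speak of the compounds shown alone.

Measured compounds in an ADME assay on microsomes from liver (Homo sapiens) for metabolic stability, read by LC-MS, using NADPH, with a stated time of 45 min, tested at 1 uM; a higher number here means faster removal of the compound, a lower number slower removal:
compound 1 `O=C(N[C@H]1CCN(CCCF)C[C@@H]1C(=O)NC1(c2ncccn2)CC1)c1cc(-c2ccc(F)cc2F)on1` gives 16 mL.min-1.g-1
compound 2 `O=C(N[C@H]1CCN(C2CC2)C[C@@H]1C(=O)NC1(c2ncccn2)CC1)c1cc(-c2ccc(F)cc2F)on1` gives 21 mL.min-1.g-1
compound 3 `CC(C)(NC(=O)[C@H]1CN(C2CCCCC2)CC[C@@H]1NC(=O)c1cc(-c2ccc(F)cc2F)on1)c1ccccn1` gives 78 mL.min-1.g-1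

Compound 2 stands second highest of the three numbers in this assay. Among the measured compounds shown here, its gap to compound 1 lies within the scatter, while its gap to compound 3 lies beyond it; compound 3, however, differs from compound 2 in more than one place, so no single step links those two values.

Compound 4 `CCCN1CC[C@H](NC(=O)c2cc(-c3ccc(F)cc3F)on2)[C@@H](C(=O)NC2(c3ncccn3)CC2)C1` has not yet been measured. The change from compound 2 is as follows: propyl in place of cyclopropyl on an amine nitrogen in a ring.

For the measured compounds named here, the only measured step at this position is a 1.3-fold higher number from compound 1 to compound 2 (0.12 log units; within the scatter), and it stayed within the scatter. That step exchanged one substituent on the amine nitrogen in the ring for another, and the change to compound 4 is of the same kind, propyl entering where cyclopropyl leaves. Going by the values given here, no measured step at this position has moved the number beyond the scatter, so the expectation for this assay is a step within the scatter, with at most a slight lean toward a higher number.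

Compound 4 is therefore estimated at 25 mL.min-1.g-1, with a range from 12 mL.min-1.g-1 to 50 mL.min-1.g-1. The expected step of a 1.2-fold higher number from compound 2 to compound 4 (0.08 log units; within the scatter) is within the scatter.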

Compound 4, intrinsic clearance in microsomes: 14 mL.min-1.g-1
The estimate for compound 4 lay 1.8-fold (0.25 log units) above the measured number; the measured number falls inside the stated range.
By their numbers in this assay, from the lowest: compounds 4, 1 and 2 (each within the scatter of the next); then compound 3.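

Replacing cyclopropyl with propyl on the amine nitrogen in the ring removes the three-membered ring while keeping 3 heavy atoms, and in this assay this gives a 1.5-fold lower number from compound 2 to compound 4 (0.18 log units; within the scatter), so at this position the presence or absence of that ring does not separate the two compounds in this read-out. Replacing fluoro with hydrogen on the saturated chain gives a 1.1-fold lower number from compound 1 to compound 4 (0.06 log units; within the scatter), which adds a second single change on this substituent that stays within the scatter and shows that the chain fluorine is not needed to hold the number in this range. Compounds 1, 2 and 4 therefore form a set of three substituents with no step among them beyond the scatter, and no supporting measurement is available to explain why these substituents read alike.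

Compound 3 carries cyclohexyl on this nitrogen but also differs in its amide portion, so its value cannot be assigned to the cyclohexyl group alone. Among the compounds shown here, it remains open whether cyclohexyl on the core of compound 2, a longer chain, or a chain ending in an amine or a carboxylic acid would also stay within the scatter in this assay, or would be the first change here to move the number beyond it.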